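Formyl in place of dichloromethyl on a shared core

This account rests on a few compounds, and the source may have more. Where it says the series, first, only, none or still open, it means among the compounds named here.

In a functional assay (Homo sapiens) (a lower number here means a stronger inhibitor, a higher number a weaker inhibitor), compound 1 (`Nc1nc2ccnc(-c3cccc(C(Cl)Cl)c3)n2n1`) gives 1000 nM, and a further entry for it carries no single number. Compound 2 (`Nc1nc2ccnc(-c3cccc(Br)c3)n2n1`), on the same core, gives 3700 nM; 3700 nM (2 entries) in this assay. Compound 3 (`Nc1nc2ccnc(-c3cccc(C=O)c3)n2n1`) awaits measurement and carries formyl in place of dichloromethyl on an aromatic carbon. Within the data shown here, no measured pair isolates this change, so only a modest loss in this assay is expected, guided loosely by compound 2 at 3700 nM; 3700 nM (2 entries). The estimated step is a 2.0-fold higher number from compound 1 to compound 3 (0.30 log units; within the scatter). Compound 3 is expected at 2000 nM, within an estimated range of 600 nM to 7000 nM.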

Compound 3, half-maximal inhibitory concentration: 700 nM
Beside the measured number, compound 3's estimate is 2.9-fold (0.46 log units) above it; measured number inside the range.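

In this assay formyl in place of dichloromethyl on an aromatic carbon, meta to a large group, gives a step that stays inside the usual scatter (a 1.4-fold lower number from compound 1 to compound 3 (0.15 log units; within the scatter)). This position therefore carries either group, one with a hydrogen-bond acceptor and one without, with no readable difference on the shared core. Nothing measured here bears on why the two groups read alike.

The compounds shown leave open how an amine, a carboxylic acid or a longer chain would read on this aromatic carbon. They also leave open whether the hydrogen-bond acceptor of formyl matters here at all.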